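Cyclopentyl Amide Variant and Expected Vero Cell Tolerance

This account rests on a few compounds, and the source may have more. Where it says the series, first, only, none or still open, it means among the compounds named here.

Measured so far:
Compound 1 `CCOC(=O)Nc1cc(N)c2[nH]c(-c3ccc(Br)cc3)nc2c1`: > 200 ug/mL in an ADME assay on Vero cells (Chlorocebus sabaeus) for cytotoxicity, with a stated time of 3 days; on this read-out higher numbers stand for weaker inhibition and lower numbers for stronger inhibition
Compound 2 `CCOC(=O)Nc1cc(NC(=O)c2ccccc2OC)c2[nH]c(-c3ccc(Br)cc3)nc2c1`: > 200 ug/mL in this assay

In this assay compound 2 gives > 200 ug/mL, which is a limit of the assay and not a number. In this assay compound 1 likewise gives > 200 ug/mL, also a limit. Within the data shown here, the only measured step, a step that the two limits leave unreadable from compound 1 to compound 2, is therefore unreadable in size and direction. What is shown is the limit of > 200 ug/mL in this assay, at which 2 of the 2 values shown sit.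

Compound 3 `CCOC(=O)Nc1cc(NC(=O)C2CCCC2)c2[nH]c(-c3ccc(Br)cc3)nc2c1` differs from compound 2 by cyclopentyl in place of 2-methoxyphenyl on a carbonyl carbon. Among the measured compounds shown here, no measured step bears on this change, and the one step that exists gives no readable size. There is thus no basis to expect a step beyond the usual scatter in this assay; compound 3 is expected to sit at the limit as well. The estimate for compound 3 is 200 ug/mL, within a range of 100 ug/mL to 400 ug/mL, meaning an expected step of a number no higher from compound 2 to compound 3 (the limit leaves the size open).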

Compound 3, half-maximal inhibitory concentration: > 200 ug/mL
Compound 3 ended at the assay's limit (the forecaster's own chance of this, stated with the estimate: 85%); the middle value lies on the limit itself.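

No new step can be read among compound 1, compound 2 and compound 3 in this assay, since each result is a limit and not a number: the limit of > 200 ug/mL in this assay, at which 3 of the 3 values shown sit.

The compounds shown leave open at what concentration any of the three would inhibit these cells, and whether cyclopentyl and 2-methoxyphenyl differ at all here.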